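Methoxy on the unsubstituted ring of the aminostilbene core

The source may report more compounds than this note shows. Statements on the series, on what has been measured and on what is new or still open speak of the compounds shown alone.

Compound 1 `Nc1cccc(/C=C/c2ccccc2)c1` is the parent of the series. In a functional assay on MCF7 cells (Homo sapiens) for inhibition, read by MTT assay, with a stated time of 2 days (on this read-out lower numbers stand for stronger inhibition and higher numbers for weaker inhibition), compound 1 gives 14 ug/mL, which is the lowest of the two numbers recorded; the nearest is compound 2 `Nc1cccc(/C=C/c2cccc(O)c2)c1`, which in this assay gives 54 ug/mL. For the measured compounds named here, the one step available, a 3.9-fold higher number from compound 1 to compound 2 (0.59 log units; beyond the scatter), shows that putting a hydroxy group on the ring that carries no amino group weakens the effect beyond the scatter.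

Compound 3 `COc1ccccc1/C=C/c1cccc(N)c1` differs from compound 1 by methoxy in place of hydrogen on an aromatic carbon, placed on an aromatic carbon of a six-membered aromatic ring of carbon only. Going by the values given here, the step from compound 1 to compound 2 is the only measured change on that same ring and it bears directly on this one, though the group and its place differ. Among the compounds with values here, no second example is available, so the size of the effect is uncertain. On this basis the number for compound 3 in this assay is expected to move upward by a modest amount, a 1.8-fold higher number from compound 1 to compound 3 (0.25 log units; within the scatter). The estimate for compound 3 is 25 ug/mL, with a range from 9 ug/mL to 70 ug/mL.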

Compound 3, half-maximal inhibitory concentration: 38.7 ug/mL
For compound 3 the middle estimate is 1.5-fold (0.19 log units) below the measured one; the measured number falls inside the stated range.
By their numbers in this assay, from the lowest: compound 1; then compounds 3 and 2 (each within the scatter of the next).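

Adding a methoxy group to this ring, ortho to a group of 9 heavy atoms, gives a 2.8-fold higher number from compound 1 to compound 3 (0.44 log units; beyond the scatter) in this assay, so this ring now has a second change that is not tolerated without loss. Read beside a 3.9-fold higher number from compound 1 to compound 2 (0.59 log units; beyond the scatter), both changes on this ring raise the number beyond the scatter, none of the shown compounds goes against that, and the rise also occurs with methoxy, a group with 0 hydrogen-bond donors, so it does not depend on the group carrying one. No measurement shown accounts for the upward step.

Going by these compounds, compounds 2 and 3 differ in both the group and its place, so the contribution of each cannot be separated, and it remains open whether hydroxy at this same place, or methoxy on another carbon of the ring, would give a similar number. On these data alone, it is also open whether the upward move extends to a smaller group such as fluorine or methyl, or to a larger one such as a longer alkoxy chain or a carboxylic acid.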